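This account rests on a few compounds, and the source may have more. Where it says the series, first, only, none or still open, it means among the compounds named here.

Measured so far in an assay for inhibition of Nitric oxide synthase, inducible (Homo sapiens), with a stated time of 30 min, tested at 1 mM; a lower number here means less inhibition, a higher number more inhibition at the concentration tested (going by the name of the read-out):
compound 1 `CC(=N)NCCC(O)c1ccccc1N` — 16.2%
compound 2 `N=C(NCCC(O)c1ccccc1N)c1ccccc1` — 64.1%

Compound 2 stands highest of the two numbers; its nearest neighbour is compound 1, the gap being a number 47.9 percentage points higher from compound 1 to compound 2 (beyond the scatter), a step in which phenyl replaced methyl on the carbon with a double bond to nitrogen. Compound 3 `N=C(NCCC(O)c1ccccc1N)c1ccc(Cl)cc1` keeps that phenyl and differs from compound 2 only by chloro in place of hydrogen on an aromatic carbon. No measured step touches that position: the one step shown, the methyl-to-phenyl exchange, concerns the whole group on the carbon with a double bond to nitrogen and says nothing about a substituent on the phenyl ring once in place. A single chlorine entering an aromatic ring is a far smaller change than the swap of phenyl for methyl, so the working expectation is a step within the scatter, a number 1.1 percentage points lower from compound 2 to compound 3 (within the scatter), with the direction not predictable from the present data. Compound 3 is therefore expected to give about 63% in this assay, most likely between 42% and 82%.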

Compound 3, a percentage reported as inhibition, at one concentration (the size of the read-out at that concentration, not a potency): 73.2%
The estimate for compound 3 lay 10.2 percentage points below the measured number; measured number inside the range.
By their numbers in this assay, from the lowest: compound 1; then compounds 2 and 3 (each within the scatter of the next).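

Among these compounds, at the position para to a large group on the phenyl ring, chloro in place of hydrogen gives a number 9.1 percentage points higher from compound 2 to compound 3 (within the scatter) in this assay, so this position accepts a chlorine with no change beyond the scatter, something the earlier compounds could not show. The benefit of an aromatic ring on the carbon with a double bond to nitrogen also holds with this substituent in place: 4-chlorophenyl in place of methyl gives a number 57 percentage points higher from compound 1 to compound 3 (beyond the scatter), and that step and a number 47.9 percentage points higher from compound 1 to compound 2 (beyond the scatter) both lie beyond the scatter. Nothing available bears on the reason for either result.

On these data alone, one chlorine at one position is a single probe, so it remains open whether a larger or differently built group there, such as methoxy, an amine or a carboxylic acid, would also stay within the scatter of compound 2. Also open, as far as these compounds go, are the effect of chloro elsewhere on the phenyl ring and whether a longer chain in place of methyl would match the phenyl group or stay with compound 1.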